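Replacing the dimethylphenyl ester of compound 3 with a fluorophenyl

The source may hold more compounds than are shown below. What is called first, only, known or untested is meant among the compounds shown, and "the series" means these compounds.

Within the data shown here, compound 3 `CCCN1CCN(c2ccc(S(=O)(=O)Oc3ccc(C)cc3C)cc2)C1=O` sits near the weaker end of the three compounds measured so far. In a functional assay on MCF7 cells (Homo sapiens) for antiproliferative activity, read by sulforhodamine B assay, with a stated time of 48 h (on this read-out lower numbers stand for stronger inhibition and higher numbers for weaker inhibition), compound 3 gives 1500 nM, which is second highest of the three numbers; compound 1 `Cc1ccc(OS(=O)(=O)c2ccc(N3CCN(C)C3=O)cc2)c(C)c1` gives 2500 nM and compound 2 `CN1CCN(c2ccc(S(=O)(=O)Oc3cccc(I)c3)cc2)C1=O` gives 560 nM. The step of a 1.7-fold lower number from compound 1 to compound 3 (0.22 log units; within the scatter) lies within the scatter, so compound 1 and compound 3 cannot be told apart on these numbers, whereas compound 2 stands apart from both.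

Compound 4 `CCCN1CCN(c2ccc(S(=O)(=O)Oc3ccc(F)cc3)cc2)C1=O` differs from compound 3 in one place: 4-fluorophenyl in place of 2,4-dimethylphenyl on an oxygen. Among the measured compounds shown here, the only measured step that touches the same position is a 4.5-fold lower number from compound 1 to compound 2 (0.65 log units; beyond the scatter), where a halogenated phenyl replaced the same 2,4-dimethylphenyl on the oxygen and the number fell by a modest amount beyond the scatter. The halogen there is iodine rather than fluorine and sits at a different position of the ring, so that step is only a partial guide. Nothing measured shows a 4-fluorophenyl directly.

On this basis compound 4 is expected to show a step of a 1.7-fold lower number from compound 3 to compound 4 (0.22 log units; within the scatter), a somewhat lower number than compound 3 but not certainly beyond the scatter. The estimate for compound 4 in this assay is 900 nM, with a range from 300 nM to 2700 nM.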

Compound 4, half-maximal inhibitory concentration: 33000 nM
The estimate for compound 4 lay 37-fold (1.56 log units) below the measured number, and the stated range ends below it.
By their numbers in this assay, from the lowest: compound 2; then compounds 3 and 1 (each within the scatter of the next); then compound 4.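

In this assay, among these compounds, the group on the oxygen whose other neighbour is the sulfonyl sulfur proves far more decisive than the earlier compounds suggested: a 22-fold higher number from compound 3 to compound 4 (1.34 log units; beyond the scatter) is a large step, and it runs opposite in direction to a 4.5-fold lower number from compound 1 to compound 2 (0.65 log units; beyond the scatter) on the otherwise different core of compound 1. Carrying a halogen on the phenyl therefore does not by itself lower the number at this position, since 3-iodophenyl in place of 2,4-dimethylphenyl lowered it while 4-fluorophenyl in place of 2,4-dimethylphenyl raised it sharply, and the two steps together show that the outcome depends on which substituted phenyl enters and possibly on the core that carries it. Nothing available bears on why this replacement cost so much.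

Because the change removes both methyl groups and adds fluorine in one step, the compounds shown cannot separate the loss of the methyl groups from the gain of fluorine. As far as these compounds go, how an unsubstituted phenyl, a chlorophenyl or the 3-iodophenyl of compound 2 would read on the core of compound 3 stays open, and with it whether the two opposite steps reflect the entering group alone.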